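This account rests on a few compounds, and the source may have more. Where it says the series, first, only, none or still open, it means among the compounds named here.

Compound 1 `CC(C)OC(=O)N1CCC(O[C@H]2CC[C@H](Oc3ccc(S(C)(=O)=O)nc3)CC2)CC1` serves as the reference point in this set. In a functional assay on isolated protein for agonist activity at Glucose-dependent insulinotropic receptor (Homo sapiens), read by HTRF and cAMP accumulation (on this read-out higher numbers stand for an effect only at larger amounts of compound and lower numbers for an effect already at smaller amounts), compound 1 gives 13 nM, the second highest of the three numbers recorded. For the measured compounds named here, its nearest neighbour is compound 2 `Cc1nc(S(C)(=O)=O)ccc1O[C@H]1CC[C@H](OC2CCN(C(=O)OC(C)C)CC2)CC1`, which in this assay gives 11 nM; the only single-point step in the set, a 1.2-fold lower number from compound 1 to compound 2 (0.07 log units; within the scatter), is a methyl in place of hydrogen on an aromatic carbon. The furthest is compound 3 `CC(C)(C)OC(=O)N1CCC(O[C@H]2CC[C@H](Oc3ccc(S(C)(=O)=O)nn3)CC2)CC1`, which gives 651 nM; it differs from compound 1 in more than one place, so its two numbers show only that a tert-butyl carbamate combined with a methylsulfonyl pyridazinyl ring sits far from compound 1.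

Compound 4 `CC(C)OC(=O)N1CCC(O[C@H]2CC[C@H](Oc3cnc(S(C)(=O)=O)cn3)CC2)CC1` is not yet measured. The change from compound 1 is 5-(methylsulfonyl)pyrazin-2-yl in place of 6-(methylsulfonyl)pyridin-3-yl on an oxygen on a saturated carbon. Going by the values given here, no measured step alters the aromatic ring alone, and the one step recorded, from compound 1 to compound 2, is within the scatter, so it offers little guidance; the gap between compound 1 and compound 3 involves a ring exchange but also a second change. The author therefore expects a modest step toward a higher number in this assay, a 3.1-fold higher number from compound 1 to compound 4 (0.49 log units; beyond the scatter), and estimates that compound 4 gives 40 nM, with a range from 10 nM to 200 nM.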

Compound 4, half-maximal effective concentration: 13.7 nM
Compound 4: the middle estimate sits 2.9-fold (0.47 log units) above what was measured, within the range that was stated.
By their numbers in this assay, from the lowest: compounds 2, 1 and 4 (each within the scatter of the next); then compound 3.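

In this assay, for the compounds shown here, the exchange on an oxygen on a saturated carbon gives a 1.1-fold higher number from compound 1 to compound 4 (0.02 log units; within the scatter); this is the first step in the set that alters the aromatic ring itself, and it leaves compound 1 and compound 4 indistinguishable on this read-out. The position therefore accepts 5-(methylsulfonyl)pyrazin-2-yl in place of 6-(methylsulfonyl)pyridin-3-yl, a ring with 2 hetero atoms for one with 1, without a readable effect, and together with a 1.2-fold lower number from compound 1 to compound 2 (0.07 log units; within the scatter) that makes two single changes to this aromatic ring, both within the scatter. Nothing available explains why the added ring nitrogen leaves the number where it is.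

The compounds shown do not separate what the ring and the tert-butyl carbamate each contribute in compound 3, which gives 651 nM in this assay. Also open, going by these compounds, is whether a nitrile or a primary amide could stand in place of the methylsulfonyl group on the pyrazine ring, and whether a methyl on that ring would read as it does in compound 2.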